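The compounds below may be only part of what the source reports. "The series", "measured", "known", "first", "only" and "open" are said of these compounds alone.

Compound 1 `COc1cc(C(=O)O)ccc1NC(=O)[C@@H]1N[C@@H](CC(C)(C)C)[C@](CNCc2ccncc2)(c2ccc(Cl)cc2F)[C@H]1c1cccc(Cl)c1F` gives 2820 nM in a functional assay on SW480 cells (Homo sapiens) for inhibition, read by CCK-8 assay, with a stated time of 4 days (on this read-out higher numbers stand for weaker inhibition and lower numbers for stronger inhibition), and compound 2 `COc1cc(C(=O)O)ccc1NC(=O)[C@@H]1N[C@@H](CC(C)(C)C)[C@](CNCc2ccccn2)(c2ccc(Cl)cc2F)[C@H]1c1cccc(Cl)c1F` gives 7050 nM as the higher of the two numbers. Compound 3 `COc1cc(C(=O)O)ccc1NC(=O)[C@@H]1N[C@@H](CC(C)(C)C)[C@](CNCc2cccnc2)(c2ccc(Cl)cc2F)[C@H]1c1cccc(Cl)c1F` is not yet measured and differs from compound 2 in one place (pyridin-3-yl in place of pyridin-2-yl on a saturated chain carbon bound to an amine nitrogen). Among the compounds with values here, the only measured step bearing on this change is a 2.5-fold higher number from compound 1 to compound 2 (0.40 log units; beyond the scatter) with pyridin-2-yl in place of pyridin-4-yl on the same saturated chain carbon, a modest one. A step of similar or smaller size towards lower numbers is therefore expected in this assay for pyridin-3-yl. The expected step is a 1.8-fold lower number from compound 2 to compound 3 (0.25 log units; within the scatter) on this single comparison. The estimate for compound 3 is 4000 nM with an expected range from 1800 nM to 9000 nM for now.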

Compound 3, half-maximal inhibitory concentration: 7310 nM
Compound 3: the middle estimate sits 1.8-fold (0.26 log units) below what was measured; the measured number falls inside the stated range.
By their numbers in this assay, from the lowest: compound 1; then compounds 2 and 3 (each within the scatter of the next).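

With pyridin-3-yl in place of pyridin-2-yl on the saturated chain carbon bound to an amine nitrogen, a 1.0-fold higher number from compound 2 to compound 3 (0.02 log units; within the scatter) appears in this assay, so these two groups cannot be told apart here. Against pyridin-4-yl, a 2.6-fold higher number from compound 1 to compound 3 (0.41 log units; beyond the scatter) is a modest step, and compound 1 is the only one of the three that stands apart from the others. Nothing available accounts for this difference.

Still open, on these data alone, is how phenyl would read on the same carbon, and whether a methoxy group on pyridin-4-yl would change the number of compound 1.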